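Shortening a Selenium-Bound Chain: From Pentyl to Methyl

The source may hold more compounds than are shown below. What is called first, only, known or untested is meant among the compounds shown, and "the series" means these compounds.

Within the data shown here, compound 2, `CCCCC[Se]c1nc(N)c2cccnc2n1`, is the only compound here with a number: in a functional assay on HTB-54 cells (Homo sapiens) for cytotoxicity, read by MTT assay, with a stated time of 72 h (a higher number here means a weaker inhibitor of growth, a lower number a stronger inhibitor of growth), compound 2 gives 8780 nM. Compound 1, `C[Se]c1nc([Se]C)c2cccnc2n1`, has no result; in this assay compound 1 shows "not determined" (no result reported). Compound 3, `C[Se]c1nc(N)c2cccnc2n1`, is not yet measured. It differs from compound 2 by hydrogen in place of butyl on a saturated chain carbon bound to a selenium atom. Among the measured compounds shown here, no step between measured compounds exists, so the direction rests on the change alone; a step of a 2.3-fold higher number from compound 2 to compound 3 (0.36 log units; beyond the scatter) toward weaker growth inhibition is expected. Compound 3 is estimated at 20000 nM, within 6000 nM to 60000 nM.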

Compound 3, concentration for 50% growth inhibition: 78200 nM
Estimate against measurement, compound 3: 3.9-fold (0.59 log units) below; the whole stated range lies below it.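

In this assay the change from pentyl to methyl gives an 8.9-fold higher number from compound 2 to compound 3 (0.95 log units; beyond the scatter) and so toward weaker growth inhibition. This first step shows that growth inhibition depends on what is carried on this saturated chain carbon bound to a selenium atom, with the pentyl compound the stronger of the pair. No measurement bearing on the cause of this step is available. The pair leaves open how a propyl chain, a longer octyl chain or a benzyl group would compare at this position. Two chain lengths alone give no trend.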